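The source may hold more compounds than are shown below. What is called first, only, known or untested is meant among the compounds shown, and "the series" means these compounds.

Compound 3 `COc1ncc(-c2ccc3nccc(-c4ccc(CN5CCCC5)cc4)c3c2)cc1NS(=O)(=O)c1ccc(F)cc1F` — 159 nM
Compound 2 `CNCCN(C)Cc1ccc(-c2ccnc3ccc(-c4cnc(OC)c(NS(=O)(=O)c5ccc(F)cc5F)c4)cc23)cc1` — 254 nM
Compound 1 `CCN(Cc1ccc(-c2ccnc3ccc(-c4cnc(OC)c(NS(=O)(=O)c5ccc(F)cc5F)c4)cc23)cc1)C1CCCCC1` — 1450 nM

All three compounds share one core and differ only in the amine carried on a saturated chain carbon bound to an aromatic carbon. In a functional assay on U-87MG ATCC cells (Homo sapiens) for cytotoxicity, read by MTT assay, with a stated time of 72 h (on this read-out lower numbers stand for stronger inhibition and higher numbers for weaker inhibition), compound 3 stands at the low end of the set: its separation from compound 1 is clear, a 9.1-fold lower number from compound 1 to compound 3 (0.96 log units; beyond the scatter), while its separation from compound 2, a 1.6-fold lower number from compound 2 to compound 3 (0.20 log units; within the scatter), stays within the scatter. Compound 2 itself is set apart from compound 1 by a 5.7-fold lower number from compound 1 to compound 2 (0.76 log units; beyond the scatter).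

Compound 4 `COc1ncc(-c2ccc3nccc(-c4ccc(CN5CCN(C)CC5)cc4)c3c2)cc1NS(=O)(=O)c1ccc(F)cc1F` is the next variation on this theme. Its change from compound 3 is 4-methylpiperazin-1-yl in place of pyrrolidin-1-yl on a saturated chain carbon bound to an aromatic carbon. The steps measured so far say that moving away from the large cyclohexyl(ethyl)amino group gives a modest gain, whereas exchanging one compact amine for another, as between compound 2 and compound 3, changes little. The new group in compound 4 is again a compact cyclic amine, so no step beyond the scatter is expected in this assay, the estimated step being a 1.4-fold higher number from compound 3 to compound 4 (0.14 log units; within the scatter). Compound 4 is therefore expected to give about 220 nM, within a range of 80 nM to 600 nM.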

Compound 4, half-maximal inhibitory concentration: 336 nM
Beside the measured number, compound 4's estimate is 1.5-fold (0.18 log units) below it, and the stated range covers the measured number.
By their numbers in this assay, from the lowest: compounds 3, 2 and 4 (each within the scatter of the next, the first and the last beyond it); then compound 1.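

Replacing the five-membered pyrrolidin-1-yl ring with the six-membered 4-methylpiperazin-1-yl ring gives, in this assay, a 2.1-fold higher number from compound 3 to compound 4 (0.32 log units; beyond the scatter). This is a modest step, but it shows that the two cyclic amines can be told apart at this saturated chain carbon, whereas the earlier comparison of the open-chain amine in compound 2 with pyrrolidin-1-yl stayed within the scatter. The open-chain amine also cannot be separated from the new ring, with a 1.3-fold higher number from compound 2 to compound 4 (0.12 log units; within the scatter), while the large cyclohexyl(ethyl)amino group remains clearly apart, with a 4.3-fold lower number from compound 1 to compound 4 (0.64 log units; beyond the scatter), so the gain seen on leaving that group also holds for 4-methylpiperazin-1-yl, and no available evidence explains any of these steps.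

Compound 4 differs from compound 3 in ring size, in the second ring nitrogen and in the methyl group all at once, so the step cannot be assigned to any one of them. A piperidin-1-yl group would keep the six-membered ring without the second nitrogen, and a piperazin-1-yl group would keep that nitrogen without the methyl, which would allow these changes to be read separately.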